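The compounds below may be only part of what the source reports. "The series", "measured", "known", "first", "only" and "open" are said of these compounds alone.

Measured in a functional assay on MDA-MB-231 cells (Homo sapiens) for inhibition, read by MTT assay, with a stated time of 48 h; on this read-out lower numbers stand for stronger inhibition and higher numbers for weaker inhibition:
- compound 1 `N#Cc1cccc(NC(=O)c2[nH]cnc2-c2nc3ccccc3[nH]2)c1`: 24900 nM
- compound 2 `O=C(NCC1CC1)c1[nH]cnc1-c1nc2ccccc2[nH]1`: 33100 nM
- compound 3 `O=C(NC1CCCC1)c1[nH]cnc1-c1nc2ccccc2[nH]1`: 20600 nM

Compound 3 gives 20600 nM, which cannot be separated from the other two values. The steps to it are a 1.2-fold lower number from compound 1 to compound 3 (0.08 log units; within the scatter) and a 1.6-fold lower number from compound 2 to compound 3 (0.21 log units; within the scatter).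

Compound 4 `O=C(NCc1ccco1)c1[nH]cnc1-c1nc2ccccc2[nH]1` carries (furan-2-yl)methyl in place of cyclopentyl on an amide-type nitrogen.

Every change measured at this nitrogen has stayed small, including a 1.3-fold higher number from compound 1 to compound 2 (0.12 log units; within the scatter). Among the compounds with values here, the closest precedent is the cyclopropylmethyl to cyclopentyl swap, a 1.6-fold lower number from compound 2 to compound 3 (0.21 log units; within the scatter). No step beyond the scatter is therefore expected in this assay, and no direction can be called with confidence.

The expected step is a 1.2-fold higher number from compound 3 to compound 4 (0.08 log units; within the scatter).

For compound 4 the estimate is 25000 nM, with an expected range of 12000 nM to 50000 nM.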

Compound 4, half-maximal inhibitory concentration: 22200 nM
Estimate against measurement, compound 4: 1.1-fold (0.05 log units) above, and the stated range covers the measured number.
By their numbers in this assay, from the lowest: compounds 3, 4, 1 and 2 (each within the scatter of the next).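

In this assay the change to (furan-2-yl)methyl, which brings an aromatic ring with a hydrogen-bond acceptor, gives a 1.1-fold higher number from compound 3 to compound 4 (0.03 log units; within the scatter) and so adds no separable effect at this nitrogen. Against the other groups, a 1.5-fold lower number from compound 2 to compound 4 (0.17 log units; within the scatter) and a 1.1-fold lower number from compound 1 to compound 4 (0.05 log units; within the scatter) also stay within the scatter, so all four compounds remain unresolved. No evidence on hand explains this flat picture.

Still open, going by these compounds, is whether an amine or a carboxylic acid on the chain at this amide-type nitrogen would give a step beyond the scatter, and whether a change on the shared core would.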